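A few compounds are considered here, and "the series" means these few. Any claim that something is new, unique, unknown or untested is made for them only; others in the source may bear on it.

Measured in a physicochemical assay for lipophilicity, measured as octanol-water partition; on this read-out higher numbers stand for higher lipophilicity and lower numbers for lower lipophilicity:
- compound 1 `CC(=O)Nc1nc2ccccc2s1`: 2.14
- compound 2 `COC(=O)Nc1nc2ccccc2s1`: 2.72
- compound 3 `CCCCC(=O)Nc1nc2ccccc2s1`: 3.63

Compound 2 stands second highest of the three, and a number 0.58 log units higher from compound 1 to compound 2 (beyond the scatter) while a number 0.91 log units higher from compound 2 to compound 3 (beyond the scatter).

The next compound is compound 4 `CNc1nc2ccccc2s1`, and the change is methyl in place of methoxycarbonyl on a nitrogen on an aromatic ring. Going by the values given here, no measured step removes the carbonyl, so none matches this change directly. The nearest guides are changes of the group on the carbonyl carbon. There, a number 0.58 log units higher from compound 1 to compound 2 (beyond the scatter) for methoxy in place of methyl, and a number 1.49 log units higher from compound 1 to compound 3 (beyond the scatter) for the longer chain. Across these three compounds the larger group goes with the higher number, so a smaller group on the nitrogen points downward in this assay. A modest fall is expected, and the size is uncertain without a direct precedent. The expected change is a number 0.37 log units lower from compound 2 to compound 4 (beyond the scatter). For compound 4 the estimated value is 2.35, with an expected range from 1.95 to 2.75.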

Compound 4, partition coefficient: 2.73
For compound 4 the middle estimate is 0.38 log units below the measured one, and the stated range covers the measured number.
By their numbers in this assay, from the lowest: compound 1; then compounds 2 and 4 (each within the scatter of the next); then compound 3.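

In this assay, methyl in place of methoxycarbonyl on a nitrogen on an aromatic ring gives a number 0.01 log units higher from compound 2 to compound 4 (within the scatter) and so leaves compound 2 and compound 4 indistinguishable on this read-out, although the group that leaves is the larger one and holds the carbonyl. Methyl in place of acetyl on the same nitrogen gives a number 0.59 log units higher from compound 1 to compound 4 (beyond the scatter) in the same assay, so removing the carbonyl does not have one fixed outcome here: the result depends on which carbonyl group leaves, and compound 4 goes against the earlier link between larger group and higher number. No measurement at hand accounts for the difference between these two exchanges.

Open, as far as these compounds go, is how the free amine, with only hydrogen on this nitrogen, would compare with compound 4. Also open, from the compounds shown here alone, is whether ethyl or a longer chain such as butyl on the same nitrogen would raise the number beyond that of compound 4.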